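A few compounds are considered here, and "the series" means these few. Any claim that something is new, unique, unknown or untested is made for them only; others in the source may bear on it.

Working notes on the coumarin-type series. Compound 1 `O=c1oc2ccccc2c(N2CCN(c3ccccc3)CC2)c1CO` is the parent of the set, carrying an unsubstituted phenyl on the ring amine nitrogen. In a toxicity assay on HEK-293T cells (Homo sapiens) for inhibition, read by MTT assay, with a stated time of 24 h (on this read-out higher numbers stand for lower toxicity in this test and lower numbers for higher toxicity in this test), compound 1 reaches only a limit, > 50000 nM, so no number is known for it. Among the compounds with values here, the one measured neighbour, compound 2 `O=c1oc2ccccc2c(N2CCN(c3cccc(C(F)(F)F)c3)CC2)c1CO`, bears a trifluoromethyl in place of hydrogen on an aromatic carbon. In this assay compound 2 likewise stops at a limit, > 50000 nM. The step that the two limits leave unreadable from compound 1 to compound 2 therefore cannot be read as a size. The only pattern in hand is the limit of > 50000 nM in this assay, at which 2 of the 2 values shown sit, which says nothing beyond the fact that neither compound showed measurable toxicity within the tested window.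

Compound 3 `O=c1oc2ccccc2c(N2CCN(c3cccc(Cl)c3Cl)CC2)c1CO` is not yet measured. Its change from compound 1 is 2,3-dichlorophenyl in place of phenyl on an amine nitrogen in a ring. Within the data shown here, no measured step bears directly on this change; the trifluoromethyl step from compound 1 to compound 2 is the nearest analogue, and it stayed at the limit on both sides. The expectation is that compound 3 stays in the same region, with a step that the limit leaves unreadable from compound 1 to compound 3 expected to be no step beyond the scatter and most likely another limit. Compound 3 is estimated at 80000 nM, within 30000 nM to 250000 nM.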

Compound 3, half-maximal cytotoxic concentration: > 50000 nM
Compound 3: no number, only a limit (the forecaster's own chance of this, stated with the estimate: 85%); the middle value lies beyond the limit too.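

In this assay compound 3 gives > 50000 nM, which is a limit and not a number. The steps from compound 1 to compound 2 and to compound 3 therefore cannot be read as sizes. The compounds shown leave open at what concentration, if any, compound 1, compound 2 or compound 3 would show toxicity in this assay.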